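Fluoro in Place of Hydroxy: What to Expect for Compound 4

The source may hold more compounds than are shown below. What is called first, only, known or untested is meant among the compounds shown, and "the series" means these compounds.

Three compounds have been measured in a functional assay on HeLa cells (Homo sapiens) for cytotoxicity, read by WST assay, with a stated time of 48 h; on this read-out higher numbers stand for weaker inhibition and lower numbers for stronger inhibition:
compound 1 `COc1ccc([C@H](O)[C@H]2CO[C@H](c3ccc(OC)c(OC)c3)[C@@H](C/C=C/c3ccc(OC)c(OC)c3)C2)cc1` gives 46000 nM
compound 2 `Oc1ccc(/C=C/C[C@H]2C[C@@H]([C@@H](O)c3ccccc3)CO[C@@H]2c2ccccc2)cc1` gives 14400 nM
compound 3 `COc1ccc(/C=C/C[C@H]2C[C@@H]([C@@H](O)c3ccc(OC)c(OC)c3)CO[C@@H]2c2ccc(OC)c(OC)c2)cc1OC` gives 23800 nM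

Compound 2 has the lowest of the three numbers. Its nearest neighbour is compound 3, whose number lies higher by an amount within the scatter, so no order between the two can be stated; compound 1 lies furthest away, at a distance beyond the scatter. Among the compounds with values here, only one step between compounds that differ in a single place is available: a 1.9-fold lower number from compound 1 to compound 3 (0.29 log units; within the scatter), a change that leaves the number within the scatter.

Compound 4 `O[C@@H](c1ccccc1)[C@H]1CO[C@H](c2ccccc2)[C@@H](C/C=C/c2ccc(F)cc2)C1` has not been measured. It differs from compound 2 in one place: fluoro in place of hydroxy on an aromatic carbon. Within the data shown here, no measured pair shows fluoro in place of hydroxy, so the only guide is the one small step above together with the narrow spread of the three numbers. Compound 4 is therefore expected to stay close to compound 2 in this assay, the estimated step being a 1.3-fold higher number from compound 2 to compound 4 (0.10 log units; within the scatter). Compound 4 is estimated at 18000 nM, with a range from 7000 nM to 45000 nM.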

Compound 4, half-maximal inhibitory concentration: 8340 nM
Beside the measured number, compound 4's estimate is 2.2-fold (0.33 log units) above it, within the range that was stated.
By their numbers in this assay, from the lowest: compounds 4, 2, 3 and 1 (each within the scatter of the next, the first and the last beyond it).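

Within the data shown here, compound 4 gives the first reading at the far end of the 3-(4-hydroxyphenyl)prop-2-en-1-yl side chain, where the only earlier step had concerned methoxy in place of hydrogen: in this assay, fluoro in place of hydroxy gives a 1.7-fold lower number from compound 2 to compound 4 (0.24 log units; within the scatter), a step within the scatter, so no order between the two compounds can be stated. By the counts for the two groups, the hydroxy brings one hydrogen-bond donor and one hydrogen-bond acceptor and the fluoro brings neither, so the loss of both at this place, on an aromatic carbon para to a large group, leaves the number unchanged within the scatter. Nothing available here explains this result.

From the compounds shown here alone, one exchange at this place cannot show how far the tolerance extends, and it remains open whether an amine, a carboxylic acid or a longer chain in the same spot would also stay within the scatter of compound 2. Going by these compounds, it is also open whether the same exchange would behave alike on the methoxy-bearing rings of compound 3, since compound 2 and compound 4 carry unsubstituted phenyl rings elsewhere.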